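The source may report more compounds than this note shows. Statements on the series, on what has been measured and on what is new or still open speak of the compounds shown alone.

Measured compounds:
compound 1, `CCOC(=O)c1cccc(-c2ccc(OC)cc2)c1`, 77%
compound 2, `CCOC(=O)c1cccc(-c2ccc(N(C)C)cc2)c1`, 87%
compound 3, `CCOc1ccc(-c2ccccc2)cc1`, 35%

In an assay on COS-7 cells for inhibition of patatin-like phospholipase domain-containing protein 2 (Mus musculus), tested at 200 uM (a higher number here means more inhibition at the concentration tested (going by the name of the read-out), a lower number less inhibition), compound 3 gives the lowest of the three numbers: compound 1 lies well above it, and compound 2 further still, both gaps beyond the scatter. Compound 4, `CCOc1ccc(-c2cccc(NC(=O)N(C)C)c2)cc1`, is compound 3 with one change: (dimethylcarbamoyl)amino in place of hydrogen on an aromatic carbon. The new group sits on an aromatic carbon of the six-membered ring of carbon only, in the position given as meta to a group of 9 heavy atoms. Among the compounds with values here, the only measured step, a number 10 percentage points higher from compound 1 to compound 2 (within the scatter), swaps one small group for another on the other ring of a different pair and so says little about adding a (dimethylcarbamoyl)amino group to a ring that carried only hydrogen. Compounds 1 and 2, which carry a group on that ring, both sit far above compound 3, but that is two compounds, not a rule. A moderate rise is therefore expected, a number 15 percentage points higher from compound 3 to compound 4 (beyond the scatter), and compound 4 is estimated at 50%, between 20% and 80%.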

Compound 4, a percentage reported as inhibition, at one concentration (the size of the read-out at that concentration, not a potency): 68%
The estimate for compound 4 lay 18 percentage points below the measured number, and the stated range covers the measured number.
By their numbers in this assay, from the lowest: compound 3; then compounds 4, 1 and 2 (each within the scatter of the next, the first and the last beyond it).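

In this assay, a (dimethylcarbamoyl)amino group on a ring that otherwise carried only hydrogen gives a number 33 percentage points higher from compound 3 to compound 4 (beyond the scatter), a large step. Within the data shown here, this is the first direct look at this position, on an aromatic carbon meta to a group of 9 heavy atoms, and it shows that filling it with this group raises the inhibition read at the tested concentration, whereas the earlier step only swapped one small group for another on a different pair. No measurement available here explains the rise.

With only one group shown at this position, it remains open whether a simple amine or a methyl group would bring a similar rise. Also open, from the compounds shown here alone, is whether a carboxylic acid would do so, or the same (dimethylcarbamoyl)amino group on another aromatic carbon of this ring.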